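A few compounds are considered here, and "the series" means these few. Any claim that something is new, unique, unknown or untested is made for them only; others in the source may bear on it.

Compound 1 `Cc1cccc(NC[C@@H]2CC3(CC3)CN2C(=O)c2nc(C)sc2-c2ccccc2)n1` was tested in a functional assay on CHO cells for antagonist activity at Orexin/Hypocretin receptor type 1 (Homo sapiens), read by FLIPR and calcium flux (on this read-out lower numbers stand for lower potency and higher numbers for higher potency (the scale is a negative logarithm)), and gives 7.3. Among the three measured compounds it does not stand alone: compound 3 `Cc1ccc(-c2ncccn2)c(C(=O)N2CCC3(CC3)C[C@H]2CNc2ccc(Cl)cn2)c1` gives 7.6, a number that lies within the usual scatter of the value for compound 1, so the two cannot be told apart. Compound 2 `O=C(c1nc(C(F)(F)F)ccc1-c1ncccn1)N1CC2(CC2)C[C@H]1CNc1ccc(C(F)(F)F)cn1` gives 6.7, a number that lies beyond the scatter below compound 1. Compound 4 `Cc1nc(C(=O)N2CC3(CC3)C[C@H]2CNc2ccc(Cl)cn2)c(-c2ccccc2)s1` has not yet been measured. It differs from compound 1 in a single place: 5-chloropyridin-2-yl in place of 6-methylpyridin-2-yl on an amine nitrogen. Within the data shown here, no measured pair shows exactly this exchange, so its effect has to be guessed from the neighbours. Compound 3 carries the same 5-chloropyridin-2-yl group on its amine nitrogen and gives 7.6, though its core is a different one. On that basis a step from compound 1 to compound 4 of a number 0.10 log units higher from compound 1 to compound 4 (within the scatter) is expected, that is, no change beyond the scatter in either direction. Compound 4 is therefore estimated at 7.4, with a range from 6.8 to 8.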

Compound 4, negative logarithm of the antagonist equilibrium constant: 8.3
Beside the measured number, compound 4's estimate is 0.90 log units below it, and the stated range ends below it.
By their numbers in this assay, from the lowest: compound 2; then compounds 1 and 3 (each within the scatter of the next); then compound 4.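

Within this assay and with everything else in the molecule unchanged, 5-chloropyridin-2-yl in place of 6-methylpyridin-2-yl on an amine nitrogen gives a number 1.00 log units higher from compound 1 to compound 4 (beyond the scatter) and so provides the first direct reading of this exchange. It shows that this position is sensitive to the choice of group, even though the two pyridine rings match in size and in their counts of hetero atoms and hydrogen-bond acceptors. No measurement shown here speaks to the reason for this step.

The exchange alters both the substituent and its ring position, so 5-methylpyridin-2-yl and 6-chloropyridin-2-yl would be needed to separate the two changes. Going by these compounds, whether the same exchange has a similar effect on other cores also remains open.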